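Closing a Dialkylamine into a Ring on the Core

The compounds below may be only part of what the source reports. "The series", "measured", "known", "first", "only" and "open" are said of these compounds alone.

Of the compounds shown here, two have been measured in a functional assay on CHO-K1 cells for antagonist activity at transient receptor potential cation channel subfamily V member 1 (Homo sapiens), read by FLIPR; a higher number here means a weaker inhibitor, a lower number a stronger inhibitor. Compound 1 `CC(C(=O)NCc1ccc(C(F)(F)F)nc1NCC1CCN(C(=O)OC(C)(C)C)CC1)c1ccc(NS(C)(=O)=O)c(F)c1` gives 1140 nM. Compound 2 `CCCN(CCC)c1nc(C(F)(F)F)ccc1CNC(=O)C(C)c1ccc(NS(C)(=O)=O)c(F)c1` gives 14.7 nM, the lower of the two numbers, and the gap between them is well beyond the usual scatter of this assay. Compound 3 `COC1CCN(c2nc(C(F)(F)F)ccc2CNC(=O)C(C)c2ccc(NS(C)(=O)=O)c(F)c2)CC1` has not yet been measured; it is compound 2 with one change: 4-methoxypiperidin-1-yl in place of dipropylamino on an aromatic carbon. The dipropylamino group that leaves and the 4-methoxypiperidin-1-yl group that enters are of similar size and sit on the same aromatic carbon of the shared core. Because compound 2 already gives 14.7 nM, the expectation for compound 3 is a modest step from compound 2 to compound 3 of a 2.0-fold higher number from compound 2 to compound 3 (0.31 log units; beyond the scatter), toward a weaker inhibitor but close to the scatter. The estimate for compound 3 in this assay is 30 nM, within a range from 8 nM to 150 nM.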

Compound 3, half-maximal inhibitory concentration: 280 nM
Compound 3: middle estimate off by 9.3-fold (0.97 log units), on the low side; the measured number lies above the stated range.
By their numbers in this assay, from the lowest: compound 2; then compound 3; then compound 1.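

In this assay the swap gives a 19-fold higher number from compound 2 to compound 3 (1.28 log units; beyond the scatter) and so shows that this position, on an aromatic carbon next to the ring nitrogen, does not accept any group of similar size equally well. The change adds a six-membered non-aromatic ring and a methoxy oxygen at once, so this single step cannot be divided between the two. Nothing measured here gives a reason for the step.

The compounds shown leave open whether closing the dialkylamine into a ring or carrying the methoxy group accounts for the higher number, a question that plain piperidin-1-yl would help separate. They also leave open how a shorter open chain such as diethylamino, or an oxygen-containing ring such as morpholin-4-yl, would read at this position.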